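Changing the Group on the Amine Nitrogen of the Shared Core

The source may report more compounds than this note shows. Statements on the series, on what has been measured and on what is new or still open speak of the compounds shown alone.

Compound 1 `CCOC(=O)C1=C(N/C=N/c2cccnc2Cl)Nc2[nH]nc(C)c2C1c1ccc(N(C)C)cc1`: 4890 nM
Compound 2 `CCOC(=O)C1=C(N/C=N/c2ccccn2)Nc2[nH]nc(C)c2C1c1ccc(N(C)C)cc1`: 26200 nM

Both compounds were tested in a functional assay on HepG2 cells (Homo sapiens) for inhibition, read by MTT assay, with a stated time of 48 h; on this read-out lower numbers stand for stronger inhibition and higher numbers for weaker inhibition. Compound 2 stands with the highest number of the two; its nearest neighbour is compound 1, separated by a 5.4-fold higher number from compound 1 to compound 2 (0.73 log units; beyond the scatter). Among the measured compounds shown here, this is the only step known, and it arises at the same place as the change now considered: the group on the amine nitrogen whose other neighbour is a double-bonded ring carbon.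

Compound 3 `CCOC(=O)C1=C(N/N=C(/C(=O)Br)c2ccc(Cl)cc2)Nc2[nH]nc(C)c2C1c1ccc(N(C)C)cc1` differs from compound 2 in that position: a group of 12 heavy atoms (8 carbon, 1 nitrogen, 1 oxygen, 1 chlorine, 1 bromine; one six-membered aromatic ring of carbon only) in place of a group of 8 heavy atoms (6 carbon, 2 nitrogen; one six-membered aromatic ring with 1 hetero atom), on an amine nitrogen. For the measured compounds named here, the step of a 5.4-fold higher number from compound 1 to compound 2 (0.73 log units; beyond the scatter) shows that exchanging one group for another at this nitrogen can shift the number beyond the scatter, yet no measured pair carries a group of the kind that enters here, so the direction of the change cannot be read from the data. The expectation therefore leans toward a number between the two measured ones, with wide bounds. The step expected is a 2.2-fold lower number from compound 2 to compound 3 (0.34 log units; beyond the scatter). Compound 3 is estimated at 12000 nM, with a range from 3000 nM to 50000 nM.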

Compound 3, half-maximal inhibitory concentration: 50300 nM
For compound 3 the middle estimate is 4.2-fold (0.62 log units) below the measured one; measured number outside the range, above it.
By their numbers in this assay, from the lowest: compound 1; then compounds 2 and 3 (each within the scatter of the next).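

In this assay, among the compounds shown here, the group of 12 heavy atoms and the pyridin-2-yl group cannot be told apart, with a 1.9-fold higher number from compound 2 to compound 3 (0.28 log units; within the scatter) as the only step between them, so exchanging these two quite different groups on the amine nitrogen does not shift the number beyond the scatter. Set against the 2-chloropyridin-3-yl group, the same group of 12 heavy atoms gives a 10-fold higher number from compound 1 to compound 3 (1.01 log units; beyond the scatter), a large step, and compound 1 now stands apart from both other compounds, with the lowest number of the three and the strongest inhibition on this read-out. The compounds shown offer no evidence on why this position behaves in this way.

The compounds shown leave open whether the chlorine or the way the pyridine ring is attached sets compound 1 apart, since a pyridin-3-yl group without chlorine does not appear among them. They also leave open how this nitrogen would respond to a carboxylic acid or an amide in place of the bromine-bearing carbonyl of compound 3.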